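Tyrphostin-like acrylamides: furan to methoxyphenyl swap

The compounds below may be only part of what the source reports. "The series", "measured", "known", "first", "only" and "open" are said of these compounds alone.

Compound 1 `N#C/C(=C\c1ccco1)C(=O)NCc1ccc(Cl)c(Cl)c1` — 20000 nM
Compound 2 `COc1ccc(CNC(=O)/C(C#N)=C/c2ccoc2)cc1` — 7000 nM
Compound 3 `COc1ccc(CNC(=O)/C(C#N)=C/c2ccc(C)cc2)cc1` — 36000 nM

Three measured compounds share an acrylamide core carrying a nitrile and a benzylamide. In a functional assay on MCF7 cells (Homo sapiens) for inhibition, read by MTT assay, with a stated time of 72 h (on this read-out lower numbers stand for stronger inhibition of growth and higher numbers for weaker inhibition of growth), compound 1 gives 20000 nM, the second highest of the three numbers; it sits within the scatter of compound 3 and beyond the scatter of compound 2, whose number is lower.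

Compound 4 `COc1ccc(/C=C(\C#N)C(=O)NCc2ccc(Cl)c(Cl)c2)cc1` has not yet been measured. It differs from compound 1 by 4-methoxyphenyl in place of furan-2-yl on a double-bonded chain carbon bound to a double-bonded chain carbon. Going by the values given here, one measured step bears on this: a 5.1-fold higher number from compound 2 to compound 3 (0.71 log units; beyond the scatter), where a six-membered carbon ring replaced a furan ring on the same position. That step went in the direction of weaker growth inhibition, though the rings there were furan-3-yl and 4-methylphenyl rather than the furan-2-yl and 4-methoxyphenyl involved here, and the benzylamide also differed. A modest step toward a higher number is therefore expected, with wide uncertainty. Compound 4 is expected to give about 50000 nM in this assay, within 15000 nM to 150000 nM, meaning an expected step of a 2.5-fold higher number from compound 1 to compound 4 (0.40 log units; beyond the scatter).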

Compound 4, concentration for 50% growth inhibition: 45000 nM
Estimate against measurement, compound 4: 1.1-fold (0.05 log units) above; measured number inside the range.
By their numbers in this assay, from the lowest: compound 2; then compounds 1, 3 and 4 (each within the scatter of the next, the first and the last beyond it).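

In this assay, the result gives a direct reading of this change on a single benzylamide: 4-methoxyphenyl in place of furan-2-yl brings a 2.3-fold higher number from compound 1 to compound 4 (0.35 log units; beyond the scatter). The step runs in the same direction as a 5.1-fold higher number from compound 2 to compound 3 (0.71 log units; beyond the scatter), so in both pairs shown, a six-membered carbon ring in place of a furan ring on a double-bonded chain carbon goes with weaker growth inhibition, and neither pair goes against this, although the pairs differ in furan attachment, ring substituent and benzylamide. The hydrogen-bond acceptor count stays the same across the change, and nothing measured here explains the step.

The compounds shown leave open how the benzylamide alone affects the number, since no pair differs only there. They also leave open whether an amine or a carboxylic acid on the six-membered ring would restore growth inhibition.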